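The compounds below may be only part of what the source reports. "The series", "measured", "known", "first", "only" and "open" are said of these compounds alone.

Measured so far:
- compound 1, `O=C(Nc1ccccc1)Nc1nnc(Sc2ncnc3scc(-c4ccncc4)c23)s1`: 19300 nM
- compound 2, `O=C(Nc1ccc(F)cc1)Nc1nnc(Sc2ncnc3scc(-c4ccncc4)c23)s1`: 28300 nM
- compound 3, `COc1cccc(NC(=O)Nc2nnc(Sc3ncnc4scc(-c5ccncc5)c34)s2)c1`: 67700 nM

All three were tested in a functional assay on HUVEC cells (Homo sapiens) for antiproliferative activity, read by MTT assay, with a stated time of 48 h; a lower number here means a stronger inhibitor, a higher number a weaker inhibitor. On these numbers compound 3 stands highest, that is, it is the weakest inhibitor of the three: compound 2 is nearest to it, as a 2.4-fold higher number from compound 2 to compound 3 (0.38 log units; beyond the scatter) shows, and compound 1 is furthest, as a 3.5-fold higher number from compound 1 to compound 3 (0.55 log units; beyond the scatter) shows.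

Compound 4, `O=C(Nc1cccc(F)c1)Nc1nnc(Sc2ncnc3scc(-c4ccncc4)c23)s1`, has not yet been measured. It differs from compound 3 in one place: fluoro in place of methoxy on an aromatic carbon.

For the measured compounds named here, two measured steps bear on this change. Taking the methoxy away is the reverse of a 3.5-fold higher number from compound 1 to compound 3 (0.55 log units; beyond the scatter), so removing it should bring the number back down towards that of compound 1. Putting a fluoro onto the same ring, in another position, gave a 1.5-fold higher number from compound 1 to compound 2 (0.17 log units; within the scatter), a step within the scatter. Together these point to a modest drop in this assay for compound 4, back into the region of compounds 1 and 2.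

Compound 4 is therefore expected to give about 24000 nM, within a range of 10000 nM to 55000 nM, which would be an estimated step of a 2.8-fold lower number from compound 3 to compound 4 (0.45 log units; beyond the scatter).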

Compound 4, half-maximal inhibitory concentration: 13700 nM
Estimate against measurement, compound 4: 1.8-fold (0.24 log units) above; low and high end bracket the measured number.
By their numbers in this assay, from the lowest: compounds 4, 1 and 2 (each within the scatter of the next, the first and the last beyond it); then compound 3.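

In this assay, fluoro in place of methoxy on the same ring carbon gives a 4.9-fold lower number from compound 3 to compound 4 (0.69 log units; beyond the scatter), so the rise seen with methoxy does not follow from simply having a group at this place. Set against the bare phenyl ring, the fluoro gives a 1.4-fold lower number from compound 1 to compound 4 (0.15 log units; within the scatter), a step within the scatter, so compound 4 and compound 1 cannot be told apart and fluoro here is tolerated. Position on the ring also counts for this atom, since 3-fluorophenyl in place of 4-fluorophenyl gives a 2.1-fold lower number from compound 2 to compound 4 (0.32 log units; beyond the scatter), a modest step just beyond the scatter.

From the compounds shown here alone, whether chlorine, an amine or a carboxylic acid at this place would behave like fluoro or like methoxy stays open. Nothing shown here explains why methoxy and fluoro differ.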